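A few compounds are considered here, and "the series" means these few. Any claim that something is new, unique, unknown or untested is made for them only; others in the source may bear on it.

Four compounds share one core, each carrying a different group on the carbon that bears the carbonyl. Compound 1 `CCCSc1nc(Cl)c2c(n1)N(Cc1ccccc1)C(C(=O)N1CCN(C(=O)OC(C)(C)C)CC1)N2` carries an amide built on a protected piperazine, compound 2 `CCCSc1nc(Cl)c2c(n1)N(Cc1ccccc1)C(C(=O)O)N2` a free carboxylic acid, compound 3 `CCCSc1nc(Cl)c2c(n1)N(Cc1ccccc1)C(C(=O)NCCC1=CCc3ccccc31)N2` an amide to a chain ending in a bicyclic hydrocarbon, and compound 4 `CCCSc1nc(Cl)c2c(n1)N(Cc1ccccc1)C(C(=O)NCCNC(=O)OC(C)(C)C)N2` an amide to a chain ending in a protected amine.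

In a functional assay on MGC-803 cells (Homo sapiens) for antiproliferative activity, read by MTT assay, with a stated time of 72 h (a higher number here means a weaker inhibitor, a lower number a stronger inhibitor), compound 1 gives 32000 nM. Compound 2 reaches only (the limit of > 64000 nM in this assay, at which 1 of the 3 values shown sits), so for it this assay gives > 64000 nM, a limit rather than a number. Compound 3 gives 27000 nM, which sits within the scatter of the value for compound 1, so the two cannot be told apart.

The move to compound 4 exchanges (a group of 8 heavy atoms (5 carbon, 1 nitrogen, 2 oxygen; no ring) in place of a group of 9 heavy atoms (9 carbon; one five-membered non-aromatic ring of carbon only, one six-membered aromatic ring of carbon only), on a saturated chain carbon, two bonds along the chain from an amide-type nitrogen). Both measured amides, compound 1 and compound 3, give numbers close together, so the step from compound 3 to compound 4 is expected to be small, a 1.3-fold higher number from compound 3 to compound 4 (0.11 log units; within the scatter), with no clear direction beyond the scatter. Compound 4 is therefore estimated at 35000 nM, in a range from 14000 nM to 90000 nM.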

Compound 4, half-maximal inhibitory concentration: > 64000 nM
Compound 4 gave a limit, no number; the forecaster's own chance of this, stated with the estimate: 30%; middle value at least 1.8-fold (0.26 log units) away from the limit.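

In this assay, the end of the amide chain on this carbon matters, and the step shows this: an at least 2.3-fold higher number from compound 3 to compound 4 (0.37 log units; beyond the scatter). Exchanging the bicyclic hydrocarbon for (tert-butoxycarbonyl)amino is therefore a change the read-out can detect, which the close values of compound 1 and compound 3 gave no sign of. Compound 4 is an amide, yet its result is a limit, and so is that of compound 2, so the two limits leave the step between these compounds unreadable: the limit of > 64000 nM in this assay, at which 2 of the 4 values shown sit.

What remains open is which part of the entering group goes with the change, as the compounds shown do not separate the tert-butoxycarbonyl cap from the chain that carries it. A free amine at the chain end, or a longer chain, or a plain phenyl ring in place of the bicyclic hydrocarbon would each bear on this.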